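A chloro group added to the phenyl of compound 1

This account rests on a few compounds, and the source may have more. Where it says the series, first, only, none or still open, it means among the compounds named here.

Of the compounds shown here, two sharing one core have been tested so far. Compound 1, with the structure `c1ccc(-c2nc3sc(-c4ccccc4)cn3n2)cc1`, carries a plain phenyl on each side of the core. Compound 2, `COc1cc(-c2nc3sc(-c4ccccc4)cn3n2)cc(OC)c1OC`, carries three methoxy groups on one of the two phenyl rings. Among the compounds with values here, in a functional assay on NCI/ADR-RES cells (Homo sapiens) for inhibition, read by sulforhodamine B assay, with a stated time of 48 h, tested at 10 uM (a higher number here means more inhibition of growth at the concentration tested, a lower number less inhibition of growth), compound 1 gives 14%, the lower of the two numbers known. In this assay compound 2 gives 39%, and the gap between compound 2 and compound 1 is larger than the usual scatter of this kind of measurement.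

Compound 3, `Clc1ccc(-c2cn3nc(-c4ccccc4)nc3s2)cc1`, has not been measured yet. It differs from compound 1 only by chloro in place of hydrogen on an aromatic carbon. Within the data shown here, no measured pair separated by this change is available, so its effect cannot be read from the two numbers already known. A single chlorine on an aromatic carbon is a small change, and it is expected to move the result from compound 1 by a number 6 percentage points higher from compound 1 to compound 3 (within the scatter), that is, by no more than the scatter or a slight rise. Compound 3 is therefore estimated at 20%, within a range from 5% to 40%.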

Compound 3, percent growth inhibition at one concentration: 34%
For compound 3 the middle estimate is 14 percentage points below the measured one; low and high end bracket the measured number.
By their numbers in this assay, from the lowest: compound 1; then compounds 3 and 2 (each within the scatter of the next).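

In this assay, within the data shown here, replacing hydrogen with chloro on an aromatic carbon, para to a large group, gives a number 20 percentage points higher from compound 1 to compound 3 (beyond the scatter) and so provides the first measured pair that differs in only one place. The step from phenyl to 4-chlorophenyl, a modest one, adds a single heavy atom, yet it moves the reading by more than repeated measurements usually scatter, so this position on the ring is not indifferent to what it carries. The data available offer no measurement that explains why this single chlorine raises the growth inhibition.

One pair cannot show whether the rise is particular to chloro or would also appear with fluoro, a methyl group, a methoxy group or an amine at the same place on the ring. It also leaves open whether chloro would give a similar step at another carbon of this phenyl ring or on the second phenyl ring, and whether a second chlorine would add to the first.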